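This account rests on a few compounds, and the source may have more. Where it says the series, first, only, none or still open, it means among the compounds named here.

Compound 1, `FC(F)(F)c1ccc(-c2noc(-c3occc3Br)n2)cc1`, was examined in a functional assay on NCI-H1299 cells (Homo sapiens) for inhibition, with a stated time of 48 h, at 37 degrees C; a higher number here means a weaker inhibitor of growth, a lower number a stronger inhibitor of growth. In this assay compound 1 gives only a limit, > 10000 nM. Compound 2, `FC(F)(F)c1ccc(-c2noc(-c3occc3Cl)n2)cc1`, carries the change (chloro in place of bromo on an aromatic carbon). In this assay compound 2 likewise gives only a limit, > 10000 nM. The step that the two limits leave unreadable from compound 1 to compound 2 cannot be sized because of the limit of > 10000 nM in this assay, at which 3 of the 3 values shown sit. Compound 3, `Clc1ccc(-c2noc(-c3occc3Br)n2)nc1`, rests on a different core; the difference between the two cores is not broken down here. In this assay compound 3 again gives only a limit, > 10000 nM. Compound 4, `Clc1ccc(-c2noc(-c3occc3Cl)n2)nc1`, has not been measured in this assay. It differs from compound 3 by chloro in place of bromo on an aromatic carbon, the same kind of change as from compound 1 to compound 2, and the place is described in the same words. Since the earlier change left both of its compounds at the limit, the step that the limit leaves unreadable from compound 3 to compound 4 is expected to be small and, in the same way, not readable. Compound 4 is therefore expected to give 15000 nM, with a range from 5000 nM to 50000 nM, most probably reported again as a limit.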

Compound 4, concentration for 50% growth inhibition: > 10000 nM
Compound 4 gave a limit, no number (the forecaster's own chance of this, stated with the estimate: 85%); the middle value does not contradict the limit.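

As with compound 1 and compound 2, no step can be read from compound 3 to compound 4 in this assay, because both compounds give only a limit: the limit of > 10000 nM in this assay, at which 4 of the 4 values shown sit. The compounds shown leave open how 3-bromofuran-2-yl and 3-chlorofuran-2-yl compare in this assay, and which structural change, if any, would give a value inside its range.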